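From a trimethylcyclohexyl ether to a methoxyphenyl ether

This account rests on a few compounds, and the source may have more. Where it says the series, first, only, none or still open, it means among the compounds named here.

Going by the values given here, in an ADME assay on MDBK cells (Bos taurus) for cytotoxicity, read by MTT assay (on this read-out lower numbers stand for higher toxicity in this test and higher numbers for lower toxicity in this test), compound 2 `CC1CC(OCCCCCCN2C[C@H](O)[C@@H](O)[C@H](O)[C@H]2CO)CC(C)(C)C1` reads 250000 nM and that is the only exact number so far. Compound 1 `OC[C@@H]1[C@@H](O)[C@H](O)[C@@H](O)CN1CCCCCCOc1cc(F)ccc1F` reads > 500000 nM in this assay and that is a limit of the assay and not a number. Among the compounds with values here, the one measured step is an at least 2.0-fold lower number from compound 1 to compound 2 (0.30 log units; that floor lies within the scatter) and it starts from the limit of > 500000 nM in this assay, at which 1 of the 2 values shown sits.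

Compound 3 `COc1ccccc1OCCCCCCN1C[C@H](O)[C@@H](O)[C@H](O)[C@H]1CO` differs from compound 2 by 2-methoxyphenyl in place of 3,3,5-trimethylcyclohexyl on an oxygen on a saturated carbon and so carries 2-methoxyphenyl in place of 3,3,5-trimethylcyclohexyl on an oxygen on a saturated carbon. This runs opposite to the measured step, going from a six-membered non-aromatic ring of carbon only to a six-membered aromatic ring of carbon only, as compound 1 also carries. A small upward move is therefore expected, resting on compound 1 and an at least 2.0-fold lower number from compound 1 to compound 2 (0.30 log units; that floor lies within the scatter) alone, and it may not clear the scatter. The estimated move is a 1.8-fold higher number from compound 2 to compound 3 (0.26 log units; within the scatter) and a reading at the assay limit is also expected to be quite possible. For compound 3 the expected value is 450000 nM within an estimated range of 200000 nM to 1000000 nM on this read-out.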

Compound 3, half-maximal cytotoxic concentration: > 500000 nM
Compound 3: only a limit was reported; the forecaster's own chance of this, stated with the estimate: 55%; middle value at least 1.1-fold (0.04 log units) from the limit.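

In this assay, putting 2-methoxyphenyl in place of 3,3,5-trimethylcyclohexyl on this oxygen gives an at least 2.0-fold higher number from compound 2 to compound 3 (0.30 log units; that floor lies within the scatter), so the reversed change also has a floor that does not clear the scatter. Compound 3 gives > 500000 nM, which is a limit of the assay and not a number. With 2-methoxyphenyl in compound 3 as with 2,5-difluorophenyl in compound 1, the reading stays at the limit, so the two aromatic rings cannot be told apart, and the step between these two compounds cannot be read: the limit of > 500000 nM in this assay, at which 2 of the 3 values shown sit.

The compounds shown leave open how far the true values of compound 1 and compound 3 lie from the exact number of compound 2, and therefore whether the ring change at this oxygen has an effect beyond the scatter. They also leave open whether an amine or a carboxylic acid on the aromatic ring, or a longer chain in place of the present one, would bring the reading down to an exact number in this assay.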